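This account rests on a few compounds, and the source may have more. Where it says the series, first, only, none or still open, it means among the compounds named here.

Compound 1 `CCOC(=O)C(C)Oc1ccc(NC(=O)CSc2ccc3ccccc3c2)cc1`: in a functional assay for inhibition, read by spectrophotometry, tested at 200 ug/mL (on this read-out lower numbers stand for less inhibition and higher numbers for more inhibition at the one concentration tested (going by the name of the read-out)), compound 1 gives 31%
Compound 2 `CCOC(=O)C(C)Oc1ccc(NC(=O)COc2ccccc2Cl)cc1`: in this assay compound 2 gives 33%
Compound 3 `CCOC(=O)C(C)Oc1ccc(NC(=O)COc2ccc3ccccc3c2)cc1`: in this assay compound 3 gives 25%

Of the compounds shown here, three have been measured so far, and all three share the same core; they differ in the group joined to the amide. Compound 3 has the lowest number of the three, but its nearest neighbour is compound 1, whose number sits higher by a gap that lies within the scatter, and even compound 2, the furthest, is higher by a gap that also lies within the scatter. On these numbers the three compounds cannot be separated from one another.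

Compound 4 `CCOC(=O)C(C)(C)Oc1ccc(NC(=O)COc2ccc3ccccc3c2)cc1` has not yet been measured. It differs from compound 3 in one place: methyl in place of hydrogen on a saturated chain carbon bound to a carbonyl carbon, an oxygen on an aromatic ring and a saturated chain carbon. Within the data shown here, no pair of measured compounds shows this change, so there is no measured step to lean on. With nothing to point either way, the expectation is that the step in this assay from compound 3 to compound 4 stays within the scatter. Compound 4 is therefore estimated at 27%, with a range from 12% to 42%, which means an expected step of a number 2 percentage points higher from compound 3 to compound 4 (within the scatter).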

Compound 4, a percentage reported as inhibition, at one concentration (the size of the read-out at that concentration, not a potency): 30%
The estimate for compound 4 lay 3 percentage points below the measured number; the range from low to high includes it.
By their numbers in this assay, from the lowest: compounds 3, 4, 1 and 2 (each within the scatter of the next).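

Among these compounds, replacing hydrogen with methyl on the saturated chain carbon, which turns 1-(ethoxycarbonyl)ethoxy into 1-(ethoxycarbonyl)-1-methylethoxy, gives the first single-place comparison in this assay, with a step of a number 5 percentage points higher from compound 3 to compound 4 (within the scatter). This position therefore accepts the added methyl with numbers that cannot be told apart at the one concentration tested, though this rests on a single pair. Nothing available bears on the reason for this result.

From the compounds shown here alone, it remains open whether a larger group at this carbon, such as ethyl, or a free carboxylic acid in place of the ethyl ester, would give a step beyond the scatter. Going by these compounds, it is equally open whether the same methyl step would read alike with the amide group of compound 2.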